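The source may report more compounds than this note shows. Statements on the series, on what has been measured and on what is new or still open speak of the compounds shown alone.

Measured in an ADME assay on MT4 cells (Homo sapiens) for cytotoxicity, read by MTT assay, with a stated time of 5 days; a higher number here means that more compound is tolerated, a lower number that less compound is tolerated:
- compound 1 `Cc1cc(/C=C/C#N)cc(C)c1Oc1cc(NCCN(C)C)nc(Nc2ccc(C#N)cc2)n1`: 3040 nM
- compound 2 `Cc1cc(/C=C/C#N)cc(C)c1Oc1cc(Cl)nc(Nc2ccc(C#N)cc2)n1`: 4310 nM
- compound 3 `Cc1cc(/C=C/C#N)cc(C)c1Oc1cc(NC2CC2)nc(Nc2ccc(C#N)cc2)n1`: 3000 nM

Given the usual scatter of repeated measurements, compound 3 at 3000 nM cannot be told apart from compound 1 or compound 2. Compound 4 `COC(Nc1cc(Oc2c(C)cc(/C=C/C#N)cc2C)nc(Nc2ccc(C#N)cc2)n1)OC` carries dimethoxymethyl in place of cyclopropyl on a nitrogen on an aromatic ring. Within the data shown here, the closest precedent is another change of the group on that nitrogen, a 1.0-fold lower number from compound 1 to compound 3 (0.01 log units; within the scatter). Changes involving chloro gave a 1.4-fold higher number from compound 1 to compound 2 (0.15 log units; within the scatter) and a 1.4-fold lower number from compound 2 to compound 3 (0.16 log units; within the scatter). On these data alone, all three steps stayed within the scatter, although dimethoxymethyl itself is untested. In this assay the expected result is a 1.1-fold higher number from compound 3 to compound 4 (0.03 log units; within the scatter), with no step beyond the scatter. Compound 4 is estimated at 3200 nM, with an expected range of 1600 nM to 6500 nM.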

Compound 4, half-maximal cytotoxic concentration: 3470 nM
For compound 4 the middle estimate is 1.1-fold (0.04 log units) below the measured one, within the range that was stated.
By their numbers in this assay, from the lowest: compounds 3, 1, 4 and 2 (each within the scatter of the next).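

In this assay, dimethoxymethyl on this nitrogen loses the ring of cyclopropyl and brings two hydrogen-bond acceptors, yet the step is a 1.2-fold higher number from compound 3 to compound 4 (0.06 log units; within the scatter). The comparisons with the other two compounds also stay within the scatter, at a 1.1-fold higher number from compound 1 to compound 4 (0.06 log units; within the scatter) and a 1.2-fold lower number from compound 2 to compound 4 (0.09 log units; within the scatter), so an open-chain group carrying oxygen joins the amines and chloro without separating from them. Nothing measured here offers an explanation for this flat result.

On these data alone, whether a carboxylic acid or a longer alkyl chain on this nitrogen would shift the number beyond the scatter remains open. So does the effect of changes elsewhere on the shared core.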